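The source may report more compounds than this note shows. Statements on the series, on what has been measured and on what is new or still open speak of the compounds shown alone.

Compound 1 `CCCOCNc1n[n+]([O-])c2cc(OC)ccc2[n+]1[O-]`: in a functional assay on PC-3 cells (Homo sapiens) for cytotoxicity, read by MTT assay, with a stated time of 72 h (a lower number here means a stronger inhibitor, a higher number a weaker inhibitor), compound 1 gives 6570 nM.
Compound 2 `CCCCOCNc1n[n+]([O-])c2ccccc2[n+]1[O-]`: in this assay compound 2 gives 14700 nM.
Compound 3 `COc1ccc2c(c1)[n+]([O-])nc(NCOC(C)c1ccccc1)[n+]2[O-]`: in this assay compound 3 gives 4140 nM.

Compound 2 has the highest number of the three, meaning it is the weakest of these inhibitors in this assay; compound 1 is its nearest neighbour and compound 3 the furthest, and both gaps are beyond the usual scatter. Compound 4 `[O-][n+]1nc(NCOCc2ccccc2)[n+]([O-])c2ccccc21` has not yet been measured. It differs from compound 2 in one place: phenyl in place of propyl on a saturated chain carbon bound to an oxygen on a saturated carbon. One measured step speaks to this kind of change. There, a propyl on an oxygen on a saturated carbon was replaced by a 1-phenylethyl, and the result was a 1.6-fold lower number from compound 1 to compound 3 (0.20 log units; within the scatter). That swap also puts an aromatic ring where a short chain sat, and it hardly moved the number. The step from compound 2 to compound 4 is therefore expected to be small as well, at most a modest drop, estimated as a 1.5-fold lower number from compound 2 to compound 4 (0.19 log units; within the scatter). On that basis compound 4 is expected to give about 9500 nM in this assay, with a likely range from 4500 nM to 20000 nM.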

Compound 4, half-maximal inhibitory concentration: 13400 nM
Compound 4: the middle estimate sits 1.4-fold (0.15 log units) below what was measured, within the range that was stated.
By their numbers in this assay, from the lowest: compounds 3 and 1 (each within the scatter of the next); then compounds 4 and 2 (each within the scatter of the next).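

On a saturated chain carbon bound to an oxygen on a saturated carbon, the change from butyl to benzyl gives a 1.1-fold lower number from compound 2 to compound 4 (0.04 log units; within the scatter) in this assay. The earlier step showed this kind of swap only on the core of compound 1, with a branched 1-phenylethyl group, whereas this one shows that an unbranched benzyl group on the core of compound 2 also stays within the scatter. Nothing measured here explains why the number holds when a six-membered aromatic ring enters the chain.

Going by these compounds, what an amine or a carboxylic acid at this place would do remains open, as does the effect of a longer chain such as hexyl. On these data alone, it is also open whether a fluorine atom on the aromatic ring of the benzyl group would move the number beyond the scatter.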